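Arylidene thiazolidinone series: furan-2-yl replacement for 4-methylphenyl

The source may report more compounds than this note shows. Statements on the series, on what has been measured and on what is new or still open speak of the compounds shown alone.

Measured compounds in a functional assay on MCF7 cells (Homo sapiens) for cytotoxicity, read by sulforhodamine B assay, with a stated time of 72 h; a lower number here means a stronger inhibitor, a higher number a weaker inhibitor:
- compound 1 `Cc1c(-c2csc(/N=C3\S/C(=C\c4ccc(Cl)cc4)C(=O)N3c3ccccc3)n2)c(=O)n(-c2ccccc2)n1C` gives > 100000 nM
- compound 2 `Cc1ccc(/C=C2\S/C(=N\c3nc(-c4c(C)n(C)n(-c5ccccc5)c4=O)cs3)N(c3ccccc3)C2=O)cc1` gives > 100000 nM

Compound 2 sits only at a limit of this assay, not at a number. The same holds for compound 1, whose value is also a limit, so the step that the two limits leave unreadable from compound 1 to compound 2 cannot be read in size; both values rest on (the limit of > 100000 nM in this assay, at which 2 of the 2 values shown sit).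

Compound 3 `Cc1c(-c2csc(/N=C3\S/C(=C\c4ccco4)C(=O)N3c3ccccc3)n2)c(=O)n(-c2ccccc2)n1C` differs from compound 2 by furan-2-yl in place of 4-methylphenyl on a double-bonded chain carbon bound to a double-bonded ring carbon. No measured step bears on this change: the only step shown, from compound 1 to compound 2, concerns a different position and is unreadable. The shared core and the rest of the scaffold are unchanged, and both measured members have given no number in this assay. Compound 3 is therefore expected to remain near the limit, with the step of a number no higher from compound 2 to compound 3 (the limit leaves the size open) expected to be none beyond the scatter. The estimate for compound 3 is 100000 nM, ranging from 30000 nM to 300000 nM.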

Compound 3, half-maximal inhibitory concentration: 22400 nM
Beside the measured number, compound 3's estimate is 4.5-fold (0.65 log units) above it; the measured number lies below the stated range.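

For the compounds shown here, the double-bonded chain carbon bound to a double-bonded ring carbon is the first place where a change gives a readable step in this assay: furan-2-yl in place of 4-methylphenyl gives an at least 4.4-fold lower number from compound 2 to compound 3 (0.64 log units; beyond the scatter), and furan-2-yl in place of 4-chlorophenyl gives an at least 4.4-fold lower number from compound 1 to compound 3 (0.64 log units; beyond the scatter). Both steps replace a six-membered aromatic ring of carbon only with a five-membered aromatic ring with 1 hetero atom. The full size of these two steps and the step from compound 1 to compound 2 cannot be read, because compound 1 and compound 2 stand at a limit of the assay: the limit of > 100000 nM in this assay, at which 2 of the 3 values shown sit.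

The compounds shown do not separate the ring oxygen of furan-2-yl from the change in ring size. From the compounds shown here alone, whether thiophen-2-yl or pyridin-2-yl on this carbon would give a similar step remains open.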